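Ethoxy in place of methyl on compound 2

A few compounds are considered here, and "the series" means these few. Any claim that something is new, unique, unknown or untested is made for them only; others in the source may bear on it.

In a functional assay on the whole organism for agonist activity, with Mus musculus as the target (on this read-out lower numbers stand for an effect already at smaller amounts and higher numbers for an effect only at larger amounts of compound), compound 1 `CC(=O)N(C)C(C)C#CCn1ccnc1` gives 3 mg/kg. Compound 2 `CC(=O)N(C)C(C)C#CCn1cncc1C` has no number, only a limit: > 100 mg/kg. Compound 3 `CC(=O)N(C)CC#CCn1cncc1C` also has only a limit: > 100 mg/kg. Compound 2 therefore stands at the limit of > 100 mg/kg in this assay, at which 2 of the 3 values shown sit.

Methyl in place of hydrogen on an aromatic carbon gave the large at least 33-fold higher number from compound 1 to compound 2 (1.52 log units; beyond the scatter). Hydrogen in place of methyl on a saturated chain carbon gave a step that the two limits leave unreadable from compound 2 to compound 3.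

Compound 4 `CCOC(=O)N(C)C(C)C#CCn1cncc1C` differs from compound 2 by ethoxy in place of methyl on a carbonyl carbon. Within the data shown here, no measured step changes the group on this carbonyl carbon. Compound 4 keeps the methyl on the aromatic carbon that came with an at least 33-fold higher number from compound 1 to compound 2 (1.52 log units; beyond the scatter), so no recovery in this assay is expected and the number is expected to stay high. The expected size is a step that the limit leaves unreadable from compound 2 to compound 4, and a report of only a limit is the likelier outcome. For compound 4 the estimated value is 120 mg/kg, with an expected range of 30 mg/kg to 300 mg/kg.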

Compound 4, dose for half-maximal effect: > 100 mg/kg
Compound 4: only a limit was reported; the forecaster's own chance of this, stated with the estimate: 75%; the middle value does not contradict the limit.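

Compound 2 and compound 4 both carry only limits in this assay, so no step can be read between them. The compounds shown leave open what ethoxy in place of methyl on a carbonyl carbon does to the number, including on compound 1, which lacks the aromatic methyl.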